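This account rests on a few compounds, and the source may have more. Where it says the series, first, only, none or still open, it means among the compounds named here.

Series notes. The shared core of compound 1 `CCN(CC)c1ccc2cc(C(=O)c3ccc(N4CCN(C(=O)CN5CCNCC5)CC4)cc3)oc2c1` carries a ring amine with a free hydrogen; in a functional assay on A549 cells (Homo sapiens) for cytotoxicity, read by MTT assay, with a stated time of 48 h (on this read-out lower numbers stand for stronger inhibition and higher numbers for weaker inhibition), compound 1 gives 320 nM. Compound 2 `CCN(CC)c1ccc2cc(C(=O)c3ccc(N4CCN(C(=O)CN5CCN(S(=O)(=O)C6CC6)CC5)CC4)cc3)oc2c1` caps that nitrogen with cyclopropylsulfonyl, and in this assay compound 2 gives 17300 nM. Compound 3 `CCN(CC)c1ccc2cc(C(=O)c3ccc(N4CCN(C(=O)CN5CCN(S(=O)(=O)c6ccc(F)cc6)CC5)CC4)cc3)oc2c1` carries (4-fluorophenyl)sulfonyl in the same place, and in this assay compound 3 gives 33200 nM. Among the three numbers compound 2 sits second highest: the step of a 1.9-fold higher number from compound 2 to compound 3 (0.28 log units; within the scatter) is within the scatter, while the steps of a 54-fold higher number from compound 1 to compound 2 (1.73 log units; beyond the scatter) and a 100-fold higher number from compound 1 to compound 3 (2.02 log units; beyond the scatter) are large.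

Compound 4 `CCOC(=O)CN1CCN(CC(=O)N2CCN(c3ccc(C(=O)c4cc5ccc(N(CC)CC)cc5o4)cc3)CC2)CC1` is unmeasured. Its change from compound 2: (ethoxycarbonyl)methyl in place of cyclopropylsulfonyl on an amine nitrogen in a ring. For the measured compounds named here, no measured step introduces (ethoxycarbonyl)methyl; the sulfonyl steps bear on it only indirectly. Because a 54-fold higher number from compound 1 to compound 2 (1.73 log units; beyond the scatter) and a 100-fold higher number from compound 1 to compound 3 (2.02 log units; beyond the scatter) each raised the number strongly on entry of a sulfonyl onto the free ring nitrogen, removal of cyclopropylsulfonyl is expected to lower it. On these data alone, what the entering group does on its own is untested, and a full return to the level of compound 1 is not assumed. The resulting step is estimated as a 12-fold lower number from compound 2 to compound 4 (1.06 log units; beyond the scatter). Compound 4 is expected to give 1500 nM in this assay, with a range of 300 nM to 8000 nM.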

Compound 4, half-maximal inhibitory concentration: > 40000 nM
Compound 4: only a limit was reported (the forecaster's own chance of this, stated with the estimate: 5%); at least 26-fold (1.42 log units) between middle value and limit.
By their numbers in this assay, from the lowest: compound 1; then compounds 2 and 3 (each within the scatter of the next). At a limit, above all of these: compound 4.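

Compound 4 in this assay gives a limit, not a number: the limit of > 40000 nM in this assay, at which 1 of the 4 values shown sits. The rise on capping the ring nitrogen now also appears with a cap that holds no sulfonyl, in an at least 120-fold higher number from compound 1 to compound 4 (2.09 log units; beyond the scatter), so among the compounds shown it is not tied to the sulfonyl link, and all three capped compounds stand far from the free amine of compound 1. Exchanging one cap for the other brings no recovery: an at least 2.3-fold higher number from compound 2 to compound 4 (0.36 log units; beyond the scatter) is a rise beyond the scatter, while an at least 1.2-fold higher number from compound 3 to compound 4 (0.08 log units; that floor lies within the scatter) has a floor within the scatter, so compound 4 is not separated from compound 3 on this evidence.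

On these data alone, with only a limit for compound 4, how far (ethoxycarbonyl)methyl lies from either sulfonyl cap remains unknown. Also open, as far as these compounds go, is whether any substituent on this nitrogen keeps the level of compound 1, for example a small methyl group, a free carboxylic acid in place of the ethyl ester, or a longer chain ending in a primary amine.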